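A few compounds are considered here, and "the series" means these few. Any claim that something is new, unique, unknown or untested is made for them only; others in the source may bear on it.

Three compounds share one core and were read for agonist activity. Compound 1 `Cc1ccc2[nH]c(C(=O)N[C@H]3CN(S(=O)(=O)c4ccnnc4)C[C@@H]3C(=O)NCCN(C)C)cc2c1` gives 89% in a functional assay on HEK293 cells for agonist activity at growth hormone secretagogue receptor type 1 (Homo sapiens), read by HTRF and inositol phosphate accumulation, with a stated time of 90 min, in the presence of a further agent that is not named here; a higher number here means a larger maximal response, a lower number a smaller maximal response. Compound 2 `Cc1ccc2[nH]c(C(=O)N[C@H]3CN(S(=O)(=O)c4ccccc4)C[C@@H]3C(=O)NC[C@H]3CCCN3C)cc2c1` gives 98% in this assay, and compound 3 `Cc1ccc2[nH]c(C(=O)N[C@H]3CN(S(=O)(=O)c4ccccc4)C[C@@H]3C(=O)N[C@@H]3CCCN(C)C3)cc2c1` gives 91% in this assay. Compound 3 thus stands second of the three numbers, though its gaps to both other compounds lie within the scatter. Compound 4 `Cc1ccc2[nH]c(C(=O)N[C@H]3CN(S(=O)(=O)c4ccccc4)C[C@@H]3C(=O)N[C@H]3CCCNC3)cc2c1` differs from compound 3 in one place: piperidin-3-yl in place of 1-methylpiperidin-3-yl on an amide-type nitrogen. For the measured compounds named here, the only measured step on that amide-type nitrogen, a number 7 percentage points lower from compound 2 to compound 3 (within the scatter), exchanged one whole substituent for another and stayed within the scatter; no measured step puts piperidin-3-yl in place of 1-methylpiperidin-3-yl, so that step bears on the present change only loosely. A step within the scatter is therefore expected, no change at the digits printed from compound 3 to compound 4 (within the scatter). Compound 4 is expected to give 91%, with a range from 80% to 100%.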

Compound 4, largest response reached (Emax), in percent of the reference or control that the assay uses: 98%
Compound 4: middle estimate off by 7 percentage points, on the low side; low and high end bracket the measured number.
By their numbers in this assay, from the lowest: compounds 1, 3, 2 and 4 (each within the scatter of the next).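

For the compounds shown here, on the amide-type nitrogen, piperidin-3-yl in place of 1-methylpiperidin-3-yl gives a number 7 percentage points higher from compound 3 to compound 4 (within the scatter), the first measured step at this position that keeps the six-membered non-aromatic ring and loses only the methyl. Piperidin-3-yl in place of (1-methylpyrrolidin-2-yl)methyl gives no change at the digits printed from compound 2 to compound 4 (within the scatter), so in this assay all three substituents on this nitrogen lie within the scatter of one another. No available evidence accounts for these results. The compounds shown leave open whether a cyclohexyl group or a carboxylic acid-bearing chain on this nitrogen would also stay within that scatter.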